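A Ring Rearrangement on the Ether Side Chain

A few compounds are considered here, and "the series" means these few. Any claim that something is new, unique, unknown or untested is made for them only; others in the source may bear on it.

Compound 1 `CNC(=O)c1cc(-c2ccc(NS(=O)(=O)c3cccc(Cl)c3Cl)cc2)nc2[nH]ncc12`, in an assay for inhibition of serine/threonine-protein kinase Sgk1 (Homo sapiens), with stated times of 30 min and 60 min, in the presence of a further agent that is not named here (on this read-out higher numbers stand for weaker inhibition and lower numbers for stronger inhibition), gives 4 nM.
Compound 2 `CN1CCC(CNC(=O)c2cc(-c3ccc(NS(=O)(=O)c4cccc(Cl)c4Cl)cc3)nc3[nH]ncc23)C1`, in this assay , gives 14 nM.
Compound 3 `Cc1n[nH]c2nc(-c3ccc(NS(=O)(=O)c4cc(Cl)ccc4F)cc3)nc(OCC3(CN)COC3)c12`, in this assay , gives 1 nM.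

Compound 3 stands lowest of the three numbers; the value of compound 1 lies closest to it and the value of compound 2 furthest away, both gaps beyond the scatter. Compound 4 `Cc1n[nH]c2nc(-c3ccc(NS(=O)(=O)c4cc(Cl)ccc4F)cc3)nc(OCC3CNCCO3)c12` differs from compound 3 by morpholin-2-yl in place of 3-(aminomethyl)oxetan-3-yl on a saturated chain carbon bound to an oxygen on an aromatic ring; the two have the same atoms, joined differently. Within the data shown here, the only measured step, a 3.5-fold higher number from compound 1 to compound 2 (0.54 log units; beyond the scatter), concerns the amide side of the shared core and adds a ring rather than rearranging one, so it bears on the present change only loosely, as a sign that side-chain alterations have moved the number by a modest amount. Among the measured compounds shown here, no measured step touches the ether side chain. Accordingly, only a small change is expected, a 2.0-fold higher number from compound 3 to compound 4 (0.30 log units; within the scatter), with no firm direction. Compound 4 is estimated at 2 nM, within a range from 0.5 nM to 8 nM.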

Compound 4, half-maximal inhibitory concentration: 2 nM
Beside the measured number, compound 4's estimate shows no gap at the digits printed; low and high end bracket the measured number.
By their numbers in this assay, from the lowest: compounds 3, 4 and 1 (each within the scatter of the next, the first and the last beyond it); then compound 2.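

Among these compounds, the step (a 2.0-fold higher number from compound 3 to compound 4 (0.30 log units; within the scatter)) is the first measured change on the ether side chain, and in this assay it shows that this position accepts morpholin-2-yl in place of 3-(aminomethyl)oxetan-3-yl with no difference that stands clear of the scatter. The two groups share the same counts of heavy atoms, hydrogen-bond donors and acceptors, so the comparison isolates how those atoms are joined, and here a four-membered ring with an aminomethyl group and a six-membered ring cannot be told apart. Nothing at hand accounts for this outcome.

Going by these compounds, what remains open is how this position would respond to a group without the amine, such as a plain methoxy, or to a carboxylic acid. Also open, on these data alone, is whether morpholin-2-yl would read the same on the core of compound 1.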